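The source may report more compounds than this note shows. Statements on the series, on what has been measured and on what is new or still open speak of the compounds shown alone.

Of the compounds shown here, two carry numbers so far. In a functional assay on A2780 cells (Homo sapiens) for inhibition, read by trypan blue exclusion, with a stated time of 72 h (on this read-out higher numbers stand for weaker inhibition of growth and lower numbers for stronger inhibition of growth), compound 1 `CCCn1c(-c2ccc(O)c(O)c2)c(C)c2cc(O)ccc21` gives 8400 nM, while compound 2 `Cc1c(-c2ccc(O)cc2)n(CCCOc2ccccc2)c2ccc(O)cc12` gives 2200 nM, the lower of the two, with compound 1 beyond the scatter above it. Compound 3 `Cc1c(-c2ccc(O)c(O)c2)n(CCCOc2ccccc2)c2ccc(O)cc12` differs from compound 2 by hydroxy in place of hydrogen on an aromatic carbon. For the measured compounds named here, no measured pair isolates this change, so there is no firm footing for its size; the step from compound 2 to compound 3 is expected to stay within the scatter, a 1.4-fold higher number from compound 2 to compound 3 (0.13 log units; within the scatter). For compound 3 in this assay the estimate is 3000 nM, with a range from 1000 nM to 9000 nM.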

Compound 3, concentration for 50% growth inhibition: 7400 nM
The estimate for compound 3 lay 2.5-fold (0.39 log units) below the measured number; the measured number falls inside the stated range.
By their numbers in this assay, from the lowest: compound 2; then compounds 3 and 1 (each within the scatter of the next).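

Hydroxy in place of hydrogen, ortho to a hydroxy group, turns 4-hydroxyphenyl into 3,4-dihydroxyphenyl and weakens growth inhibition in this assay, with a 3.4-fold higher number from compound 2 to compound 3 (0.53 log units; beyond the scatter) as the first measured pair for this change. With 3,4-dihydroxyphenyl in place, phenoxy in place of hydrogen on the saturated chain carbon gives a 1.1-fold lower number from compound 1 to compound 3 (0.06 log units; within the scatter) and so no separation between the two compounds. No evidence at hand accounts for either step.

From the compounds shown here alone, whether methoxy in place of the added hydroxy gives a similar step remains open. So does the outcome of an amine in place of phenoxy on the chain.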